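This account rests on a few compounds, and the source may have more. Where it says the series, first, only, none or still open, it means among the compounds named here.

Measured in an ADME assay on HeLa cells (Homo sapiens) for cytotoxicity, read by crystal violet staining, with a stated time of 72 h; a higher number here means that more compound is tolerated, a lower number that less compound is tolerated:
Compound 1 `CCOC(=O)c1cc(CCCOc2ccc(-c3noc(C(F)(F)F)n3)cc2OC)on1`: > 100000 nM, a limit
Compound 2 `CCOC(=O)c1cc(CCCOc2ccc(-c3noc(C(F)(F)F)n3)cc2[N+](=O)[O-])on1`: > 100000 nM, a limit
Compound 3 `Cc1cc(-c2noc(C(F)(F)F)n2)cc(C)c1OCCCc1cc(C(=O)OC(C)C)no1`: 17900 nM

Going by the values given here, compound 3 is the only one with an actual number. Compound 1 and compound 2 stand at the limit of > 100000 nM in this assay, at which 2 of the 3 values shown sit.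

The next step leads to compound 4 `CCNC(=O)c1cc(CCCOc2c(C)cc(-c3noc(C(F)(F)F)n3)cc2C)on1`, with ethylamino in place of isopropoxy on a carbonyl carbon.

Among the compounds with values here, the one measured step is a step that the two limits leave unreadable from compound 1 to compound 2. It has no readable size and concerns nitro in place of methoxy on an aromatic carbon, so it gives no guide to a change on a carbonyl carbon.

With no measured basis for a shift in this assay, the expected result is a 1.4-fold higher number from compound 3 to compound 4 (0.15 log units; within the scatter), with no change beyond the scatter anticipated.

For compound 4 the estimated value is 25000 nM, with an expected range of 9000 nM to 80000 nM.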

Compound 4, half-maximal cytotoxic concentration: > 100000 nM
Compound 4 ended at the assay's limit; the forecaster's own chance of this, stated with the estimate: 30%; at least 4.0-fold (0.60 log units) between middle value and limit.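

In this assay, ethylamino in place of isopropoxy on the carbonyl carbon gives an at least 5.5-fold higher number from compound 3 to compound 4 (0.74 log units; beyond the scatter), the only readable step shown and the only one at this place. Going by these compounds, compound 4 gives > 100000 nM, which is a limit and not a number, so the full size of the step stays unknown. Compound 3 remains the only compound with an actual number: the limit of > 100000 nM in this assay, at which 3 of the 4 values shown sit.

Still open, on these data alone, is where a carboxylic acid or a primary amide on the same carbonyl carbon would fall relative to compound 3 and compound 4. As far as these compounds go, a longer chain in place of ethylamino is equally open.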